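The source may report more compounds than this note shows. Statements on the series, on what has been measured and on what is new or still open speak of the compounds shown alone.

Measured compounds and their values:
- compound 1, `Nc1cc(N)c2nc(-c3ccccc3)c(Oc3ccc(Cl)c(Cl)c3)nc2c1`: 44700 nM
- compound 2, `Nc1cc(N)c2nc(-c3ccccc3)c(NCc3ccc(Cl)c(Cl)c3)nc2c1`: 30200 nM
- compound 3, `CCOC(=O)[C@H](CCC(=O)O)NC(=O)c1ccc(Sc2nc3cc(N)cc(N)c3nc2-c2ccccc2)cc1`: < 100000 nM (a limit, not a number)

All three share the same core and are read in a functional assay on 786-0 cells (Homo sapiens) for inhibition, read by sulforhodamine B assay, with a stated time of 48 h; on this read-out higher numbers stand for weaker inhibition of growth and lower numbers for stronger inhibition of growth. Compound 1 gives 44700 nM, the higher of the two numbers actually obtained. Its nearest neighbour is compound 2, which gives 30200 nM, and the gap between these two sits within the usual scatter, so no order can be claimed between compound 1 and compound 2. For compound 3 the assay reports only a limit, (the limit of < 100000 nM in this assay, at which 1 of the 3 values shown sits), and that value is not a number to compare against.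

The next compound, compound 4, `Nc1cc(N)c2nc(-c3ccccc3)c(Oc3ccc(F)cc3)nc2c1`, has not yet been measured. It differs from compound 1 in one place: 4-fluorophenyl in place of 3,4-dichlorophenyl on an oxygen on an aromatic ring. Going by the values given here, no pair of measured compounds differs at this position, so nothing here shows how the assay responds to the change.

Given that, the expectation for compound 4 is a modest weakening of growth inhibition, with the step expected to be a 1.6-fold higher number from compound 1 to compound 4 (0.19 log units; within the scatter), which is a step of about the size of the scatter rather than a clear shift. Compound 4 is thus estimated at 70000 nM, with a range from 25000 nM to 180000 nM, and a real chance that the assay returns only a limit.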

Compound 4, concentration for total growth inhibition: 34700 nM
Estimate against measurement, compound 4: 2.0-fold (0.30 log units) above, and the stated range covers the measured number.
By their numbers in this assay, from the lowest: compounds 2, 4 and 1 (each within the scatter of the next).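

In this assay, going by these compounds alone, 4-fluorophenyl in place of 3,4-dichlorophenyl on an oxygen on an aromatic ring gives a 1.3-fold lower number from compound 1 to compound 4 (0.11 log units; within the scatter), the first measured change at this position. The read-out therefore does not separate these two rings, even though the change removes both chlorines, brings in a fluorine and goes from 8 heavy atoms to 7 in the group. Within the data shown here, this single step shows only that this particular exchange leaves no measurable mark in the assay, and no information given here bears on why the step has this size.

On these data alone, how the read-out answers to an amine or a carboxylic acid on the phenyl ring, or to a longer chain on the oxygen in place of the ring, stays open. As far as these compounds go, the separate contribution of each halogen also stays open, as the chlorines and the fluorine change together in this one step, so it cannot yet be said whether any group at this position would move the number beyond the scatter.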